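The source may report more compounds than this note shows. Statements on the series, on what has been measured and on what is new or still open speak of the compounds shown alone.

Measured so far:
compound 1 `COc1ccc(OC(=O)C#Cc2ccccc2)cc1` gives 52600 nM;
compound 2 `O=C1C=CC2(C=C1)OC(=O)C(c1cc3ccccc3s1)=C2c1ccccc1` gives 5900 nM;
compound 3 `O=C1C=CC2(C=C1)OC(=O)C(c1ccc([N+](=O)[O-])cc1)=C2c1ccccc1` gives 5990 nM.

These numbers come from a functional assay on MCF7 cells (Homo sapiens) for antiproliferative activity, read by MTT assay, with a stated time of 48 h; a lower number here means a stronger inhibitor, a higher number a weaker inhibitor. Compound 3 and compound 2 lie within the scatter of each other, while compound 1 gives a higher number, beyond the scatter. Compound 4 `O=Cc1ccc(C2=C(c3ccccc3)C3(C=CC(=O)C=C3)OC2=O)s1` differs from compound 3 in one place: 5-formylthiophen-2-yl in place of 4-nitrophenyl on a double-bonded ring carbon. Within the data shown here, one measured step bears on this, an exchange of the aryl group on the same double-bonded ring carbon: a 1.0-fold higher number from compound 2 to compound 3 (0.01 log units; within the scatter). Among the measured compounds shown here, that step changed nothing beyond the scatter, so a further aryl swap at the same place is expected to give no step in this assay beyond the scatter. The step the estimate means, a 1.0-fold higher number from compound 3 to compound 4 (0.00 log units; within the scatter), is expected to stay within the scatter. Compound 4 is therefore expected to give about 6000 nM, between 2500 nM and 15000 nM.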

Compound 4, half-maximal inhibitory concentration: 6230 nM
The estimate for compound 4 lay 1.0-fold (0.02 log units) below the measured number; the measured number falls inside the stated range.
By their numbers in this assay, from the lowest: compounds 2, 3 and 4 (each within the scatter of the next); then compound 1.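

A third kind of aryl group on this double-bonded ring carbon again moves nothing beyond the scatter, with a 1.0-fold higher number from compound 3 to compound 4 (0.02 log units; within the scatter) and a 1.1-fold higher number from compound 2 to compound 4 (0.02 log units; within the scatter) in this assay for this swap. Compound 4 brings a five-membered aromatic ring with 1 hetero atom, so the even result now spans 1-benzothiophen-2-yl, 4-nitrophenyl and 5-formylthiophen-2-yl. No measurement shown gives a reason for this evenness. Still open, going by these compounds, is whether something other than an aryl group at this carbon, such as an amine, a carboxylic acid or a longer chain, would shift the number beyond the scatter.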